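Working notes on the ring-carbon substituent series

The source may report more compounds than this note shows. Statements on the series, on what has been measured and on what is new or still open speak of the compounds shown alone.

Measured in a functional assay on DU-145 cells (Homo sapiens) for cytotoxicity, read by MTT assay, with a stated time of 18 h; on this read-out lower numbers stand for stronger inhibition and higher numbers for weaker inhibition; every value below is a limit of the assay, not a number:
compound 1, `Cc1ccc(S(=O)(=O)N2Cc3ccccc3OC[C@@H]2C)cc1`: > 50000 nM
compound 2, `Cc1ccc(S(=O)(=O)N2Cc3ccccc3OC[C@@H]2CC(C)C)cc1`: > 50000 nM
compound 3, `Cc1ccc(S(=O)(=O)N2Cc3ccccc3OC[C@@H]2C(C)C)cc1`: > 50000 nM

Compound 3 sits at the limit of > 50000 nM in this assay, at which 3 of the 3 values shown sit, as do the other two. The steps a step that the two limits leave unreadable from compound 1 to compound 2, a step that the two limits leave unreadable from compound 1 to compound 3 and a step that the two limits leave unreadable from compound 2 to compound 3 are therefore all unreadable in size; none of them shows a direction. Compound 4, `CCC(C)[C@H]1COc2ccccc2CN1S(=O)(=O)c1ccc(C)cc1`, differs from compound 3 by methyl in place of hydrogen on a saturated chain carbon, two bonds along the chain from a saturated ring carbon. For the measured compounds named here, no measured step bears readably on this change. The expected step that the limit leaves unreadable from compound 3 to compound 4 is none beyond the scatter, with a further limit the likeliest outcome. Compound 4 is estimated at 80000 nM, between 30000 nM and 300000 nM.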

Compound 4, half-maximal inhibitory concentration: > 50000 nM
Compound 4: no number, only a limit; the forecaster's own chance of this, stated with the estimate: 85%; the middle value lies beyond the limit too.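

Compound 4 gives > 50000 nM in this assay, a limit and not a number. Its steps from compound 1, compound 2 and compound 3 cannot be read: the limit of > 50000 nM in this assay, at which 4 of the 4 values shown sit.

The compounds shown leave open whether any of these substituents on the saturated ring carbon changes the read-out at all.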